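Adding a Methoxy Group to the Benzyl Amide of Compound 3

The compounds below may be only part of what the source reports. "The series", "measured", "known", "first", "only" and "open" are said of these compounds alone.

Compound 1: `C=C1CC[C@@H]2[C@](C)(CNCc3cccc(OC)c3)[C@H](O)CC[C@@]2(C)[C@@H]1/C=C/C1=CCOC1=O`, giving 780 nM in a functional assay on BMMC cells (Mus musculus, strain C57BL/6) for inhibition, with stated times of 5 days and 48 h; on this read-out lower numbers stand for stronger inhibition and higher numbers for weaker inhibition.
Compound 2: `C=C1CC[C@@H]2[C@](C)(CNCc3ccc(OC)c(OC)c3)[C@H](O)CC[C@@]2(C)[C@@H]1/C=C/C1=CCOC1=O`, giving 3740 nM.
Compound 3: `C=C1CC[C@H]2[C@@](C)(CC[C@@H](O)[C@@]2(C)C(=O)NCc2ccccc2)[C@@H]1/C=C/C1=CCOC1=O`, giving 19400 nM.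

Compound 4, `C=C1CC[C@H]2[C@@](C)(CC[C@@H](O)[C@@]2(C)C(=O)NCc2ccc(OC)cc2)[C@@H]1/C=C/C1=CCOC1=O`, has not yet been measured. Compound 2 differs from compound 1 by methoxy in place of hydrogen on an aromatic carbon, and that change gave a 4.8-fold higher number from compound 1 to compound 2 (0.68 log units; beyond the scatter). The cores of compound 1 and compound 3 differ by benzylcarbamoyl in place of ((3-methoxybenzyl)amino)methyl on a saturated ring carbon, which gave a 25-fold higher number from compound 1 to compound 3 (1.40 log units; beyond the scatter). Compound 4 differs from compound 3 by methoxy in place of hydrogen on an aromatic carbon. The surroundings are not identical: in compound 2 the entering methoxy is ortho to a methoxy group and para to a large group, while in compound 4 it is para to a large group only, so this is the same kind of change, not the same change.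

A step toward a higher number in this assay is expected for compound 4, roughly a 1.5-fold higher number from compound 3 to compound 4 (0.19 log units; within the scatter), because a 4.8-fold higher number from compound 1 to compound 2 (0.68 log units; beyond the scatter) went the same way, though smaller since the surroundings differ. Compound 4 is therefore estimated at 30000 nM, plausibly between 10000 nM and 90000 nM.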

Compound 4, half-maximal inhibitory concentration: 6530 nM
The estimate for compound 4 lay 4.6-fold (0.66 log units) above the measured number; measured number below the stated range.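

In this assay, putting a methoxy group on the benzyl ring of the amide gave a 3.0-fold lower number from compound 3 to compound 4 (0.47 log units; beyond the scatter), so the same kind of change moved the number in opposite directions on the two cores: the same change on two cores in this assay, a 4.8-fold higher number (0.68 log units; beyond the scatter) from compound 1 to compound 2 and a 3.0-fold lower number (0.47 log units; beyond the scatter) from compound 3 to compound 4, 14-fold (1.15 log units) apart, beyond the scatter of two such steps The result shows that, among these compounds, a step measured on one core did not carry over to the other, not even in its direction. It does not show what causes the reversal, since compound 2 and compound 4 differ from their partners in the same kind of way, yet the two pairs differ both in the link to the ring, an amine in one and an amide in the other, and in whether a methoxy group was already on the ring.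

The compounds shown leave open how the plain benzylamine on the core of compound 1 would compare with its methoxy-bearing relatives. They also leave open whether a hydroxy group or a chlorine atom in place of the new methoxy on compound 4 would lower the number too.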